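The source may hold more compounds than are shown below. What is called first, only, known or untested is meant among the compounds shown, and "the series" means these compounds.

Working notes on the series. The shared core is carried by compound 1 `Cc1nn(-c2ncnc3nc[nH]c23)c2c1C(OC1CCCC1)CC(=O)N2` and compound 2 `Cc1nn(-c2ncnc3nc[nH]c23)c2c1C(C(=O)NCc1ccc(F)cc1)CC(=O)N2`; compound 1 carries a cyclopentyl ether, compound 2 an amide bearing a fluorinated benzyl group. Going by the values given here, in a functional assay on HEK293 cells for agonist activity at G-protein coupled receptor 39 (Homo sapiens), read by scintillation proximity assay and inositol phosphate accumulation, with a stated time of 75 min (a higher number here means that more compound is needed for the effect, a lower number that less compound is needed), compound 1 gives 62 nM, the lowest of the two numbers measured so far. In this assay compound 2 gives 1220 nM, a higher number, and the gap between the two values lies beyond the scatter.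

Compound 3 `COc1ccc(CCOC2CC(=O)Nc3c2c(C)nn3-c2ncnc3nc[nH]c23)cc1` has not been measured. It keeps the ether oxygen of compound 1, and the change is 2-(4-methoxyphenyl)ethyl in place of cyclopentyl on an oxygen on a saturated carbon. The group entering is a longer one with an aromatic ring and an additional acceptor, while the ether link itself stays as in compound 1 rather than becoming the amide of compound 2.

Among the compounds with values here, no measured pair with this kind of change is available, so the expectation rests on compound 1 alone. A modest step towards a higher number is expected, a 2.4-fold higher number from compound 1 to compound 3 (0.38 log units; beyond the scatter), and it may well fall within the scatter. In this assay compound 3 is estimated at 150 nM, with a range from 40 nM to 600 nM.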

Compound 3, half-maximal effective concentration: 70 nM
Compound 3: middle estimate off by 2.1-fold (0.33 log units), on the high side; the measured number falls inside the stated range.
By their numbers in this assay, from the lowest: compounds 1 and 3 (each within the scatter of the next); then compound 2.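

Going by these compounds alone, on an oxygen on a saturated carbon, 2-(4-methoxyphenyl)ethyl in place of cyclopentyl gives a 1.1-fold higher number from compound 1 to compound 3 (0.05 log units; within the scatter) in this assay, the first step that can be read at a single place. Compound 1 and compound 3 therefore cannot be told apart in this assay, although the group of 10 heavy atoms with a six-membered aromatic ring and a hydrogen-bond acceptor replaces one of 5 heavy atoms with a five-membered non-aromatic ring and no acceptor, so at this position the number is not tied to the cyclopentyl group, at least for this one pair. Nothing measured on these compounds accounts for this result.

Open, from the compounds shown here alone, is whether a plain 2-phenylethyl group without the methoxy, a small methyl ether, or a chain ending in an amine or a carboxylic acid would also give a number within the scatter of compound 1. Also open, going by these compounds, is what the ether oxygen itself contributes, which would take a compound with a carbon link in its place and the cyclopentyl group kept.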